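From methoxy to dimethylamino: an expectation for compound 4

A few compounds are considered here, and "the series" means these few. Any claim that something is new, unique, unknown or untested is made for them only; others in the source may bear on it.

Compound 1, `COc1ccc(/C=C/C(=O)NS(=O)(=O)c2ccc(C)cc2)cc1`, gives 12.2 ug/mL in a functional assay on B16-F10 cells (Mus musculus) for antiproliferative activity, read by ELISA and MTT assay, with a stated time of 48 h; on this read-out higher numbers stand for weaker inhibition and lower numbers for stronger inhibition.
Compound 2, `COc1ccc(/C=C/C(=O)NS(=O)(=O)c2ccc(Cl)cc2)cc1`, gives 5.3 ug/mL in this assay.
Compound 3, `COc1ccc(/C=C/C(=O)NS(=O)(=O)c2ccc(Br)cc2)cc1`, gives 5.8 ug/mL in this assay.

Compound 2 has the lowest number of the three. Its nearest neighbour is compound 3: a 1.1-fold higher number from compound 2 to compound 3 (0.04 log units; within the scatter). The widest gap is to compound 1: a 2.3-fold lower number from compound 1 to compound 2 (0.36 log units; beyond the scatter), and likewise a 2.1-fold lower number from compound 1 to compound 3 (0.32 log units; beyond the scatter). So compound 2 and compound 3 sit together, and compound 1 stands apart.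

Compound 4, `CN(C)c1ccc(/C=C/C(=O)NS(=O)(=O)c2ccc(Cl)cc2)cc1`, differs from compound 2 in one place: dimethylamino in place of methoxy on an aromatic carbon. Neither measured step touches this position; both concern the group on the other ring, where chloro or bromo stands in place of methyl. Among the measured compounds shown here, no measured step therefore bears directly on the change from compound 2 to compound 4, and nothing in these data points to a change in this assay beyond the scatter.

Compound 4 is therefore expected to give about 5 ug/mL, within 2.2 ug/mL to 11 ug/mL, a step of a 1.1-fold lower number from compound 2 to compound 4 (0.03 log units; within the scatter) that is expected to stay within the scatter.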

Compound 4, half-maximal inhibitory concentration: 2.8 ug/mL
The estimate for compound 4 lay 1.8-fold (0.25 log units) above the measured number; the measured number falls inside the stated range.
By their numbers in this assay, from the lowest: compounds 4, 2 and 3 (each within the scatter of the next, the first and the last beyond it); then compound 1.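

In this assay, dimethylamino in place of methoxy gives a 1.9-fold lower number from compound 2 to compound 4 (0.28 log units; within the scatter), so the first change shown at this position stays within the usual scatter and cannot be read as a real gain. Among the compounds shown here, the position, on the ring opposite the one changed in the earlier steps, therefore accepts a nitrogen-bearing group in place of an oxygen-bearing one with no measurable loss in this assay. Nothing shown here explains this outcome.

Going by these compounds, only methoxy and dimethylamino appear at this position, so it remains open whether a carboxylic acid, a hydroxyl group or a longer chain such as butoxy would shift the number beyond the scatter. Dimethylamino is also seen only with chloro on the other ring, leaving open how it would behave with methyl or bromo there.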